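A few compounds are considered here, and "the series" means these few. Any claim that something is new, unique, unknown or untested is made for them only; others in the source may bear on it.

Compound 1 `CCN(CC)c1ccc(NC(=O)c2cc(Cl)ccc2O)c(Cl)c1` is one of two compounds that have been put through an ADME assay on A549 cells (Homo sapiens) for cytotoxicity, read by resazurin assay, with a stated time of 48 h; on this read-out lower numbers stand for higher toxicity in this test and higher numbers for lower toxicity in this test. In this assay compound 1 gives 55500 nM. The other measured compound, compound 2 `O=C(Nc1ccc(NCc2cc(Cl)cc(C(F)(F)F)c2)cc1Cl)c1cc(Cl)ccc1O`, gives 30900 nM in this assay. The two numbers lie within the usual scatter of repeated measurements of each other, so on the evidence so far neither compound can be called more or less toxic than the other toward these cells.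

Compound 3 `O=C(Nc1ccc(NCc2ccncc2)cc1Cl)c1cc(Cl)ccc1O` has not yet been measured. It differs from compound 1 in one place: ((pyridin-4-yl)methyl)amino in place of diethylamino on an aromatic carbon. Among the compounds with values here, no pair of measured compounds shows what a change of this kind does in this assay, so there is nothing to calibrate the step against. Compound 2 carries a related arylmethylamino group on the same part of the shared core and gives 30900 nM, which argues for a number close to what has been seen. The step from compound 1 to compound 3 is expected to be a 1.6-fold lower number from compound 1 to compound 3 (0.20 log units; within the scatter), not beyond the scatter. Compound 3 is therefore estimated at 35000 nM, within a range of 12000 nM to 100000 nM.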

Compound 3, half-maximal cytotoxic concentration: 65300 nM
The estimate for compound 3 lay 1.9-fold (0.27 log units) below the measured number; the range from low to high includes it.
By their numbers in this assay, from the lowest: compounds 2, 1 and 3 (each within the scatter of the next, the first and the last beyond it).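

At this position, on an aromatic carbon meta to a chloro group and para to a large group, the first measured single change gives a 1.2-fold higher number from compound 1 to compound 3 (0.07 log units; within the scatter) in this assay. The exchange is not a small one: diethylamino has no ring and no hydrogen-bond donor, whereas ((pyridin-4-yl)methyl)amino brings a six-membered aromatic ring with 1 hetero atom, a hydrogen-bond donor and more heavy atoms, yet the two compounds cannot be told apart in this test of toxicity toward the cells. Nothing on hand explains this outcome, so the result stands as an observation without a known cause.

This single pair cannot show whether the same holds for other groups at this position, such as a plain amino group, a morpholin-4-yl group or a longer chain like dipropylamino, or for the isomeric ((pyridin-3-yl)methyl)amino group. It also leaves open whether changes elsewhere on the shared core, such as replacing the hydroxyl group with a methoxy group, would move the number beyond the usual scatter.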